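The source may hold more compounds than are shown below. What is called first, only, known or untested is meant among the compounds shown, and "the series" means these compounds.

Measured compounds:
compound 1 `CC(C)NC(=O)CC(c1ccc(-c2ccc3cccc(F)c3c2)[nH]c1=O)C(C)C` — 15 nM
compound 2 `CCn1ncc2c(F)cc(-c3ccc(C(CC)(CC)c4ncn(C)n4)c(=O)[nH]3)cc21` — 96 nM
compound 3 `CCn1ncc2c(F)cc(-c3ccc(C(CC)(CC)c4nnc[nH]4)c(=O)[nH]3)cc21` — 29 nM

Three compounds have a number in a functional assay on CHO cells for antagonist activity at prostaglandin E2 receptor EP3 subtype (Homo sapiens), read by cAMP accumulation; a lower number here means a stronger inhibitor, a higher number a weaker inhibitor. Compound 1 gives the lowest number of the three; compound 3 stands nearest, within the scatter, and compound 2 furthest, beyond it. Within the data shown here, compounds 2 and 3 share a core distinct from that of compound 1, and the one measured step between them, a 3.3-fold lower number from compound 2 to compound 3 (0.52 log units; beyond the scatter), concerns a five-membered aromatic ring with 3 hetero atoms on a saturated chain carbon.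

Compound 4 `CC(C)C(Cc1noc(=O)[nH]1)c1ccc(-c2ccc3cccc(F)c3c2)[nH]c1=O` is not yet measured in this assay. It differs from compound 1 in one place: a group of 6 heavy atoms (2 carbon, 2 nitrogen, 2 oxygen; one five-membered aromatic ring with 3 hetero atoms) in place of a group of 6 heavy atoms (4 carbon, 1 nitrogen, 1 oxygen; no ring), on a saturated chain carbon, two bonds along the chain from an aromatic carbon

Among the measured compounds shown here, no measured step covers this exact exchange. The step from compound 2 to compound 3 is the only one involving a five-membered aromatic ring with 3 hetero atoms at a saturated chain carbon, and it was modest and on another core, so it bears only loosely. The expectation for compound 4 is therefore a step of about a 1.3-fold lower number from compound 1 to compound 4 (0.10 log units; within the scatter) relative to compound 1, within or close to the scatter, with the direction uncertain. Compound 4 is estimated at 12 nM in this assay, with a range from 3 nM to 45 nM.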

Compound 4, half-maximal inhibitory concentration: 70 nM
For compound 4 the middle estimate is 5.8-fold (0.77 log units) below the measured one; measured number above the stated range.
By their numbers in this assay, from the lowest: compounds 1 and 3 (each within the scatter of the next); then compounds 4 and 2 (each within the scatter of the next).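

In this assay, placing the five-membered aromatic ring with 3 hetero atoms where the isopropylcarbamoyl stood, on a saturated chain carbon, two bonds along the chain from an aromatic carbon, gives a 4.7-fold higher number from compound 1 to compound 4 (0.67 log units; beyond the scatter). Among these compounds, this is the first measured change at this place on the core of compound 1: the number responds to the group even though both groups hold 6 heavy atoms, and the step, though beyond the scatter, is modest, so the ring is tolerated at some cost. The hydrogen-bond donor count stays at 1 while the acceptor count goes from 1 to 3, but no measurement on hand links either count, or any other feature of the two groups, to the step.

On these data alone, it remains open whether the isopropylcarbamoyl itself matters here or whether other groups at this place, such as a carboxylic acid, a primary amide or the 4H-1,2,4-triazol-3-yl, would return the number to that of compound 1. Also open, as far as these compounds go, is how a longer chain between the ring and the saturated chain carbon would read in this assay.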